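Trihydroxyphenyl in place of dimethoxyphenyl on a thioenone core

The compounds below may be only part of what the source reports. "The series", "measured", "known", "first", "only" and "open" are said of these compounds alone.

Measured compounds:
compound 1, `O=C(/C(=C\c1ccc(Cl)cc1)SCc1ccc(Cl)cc1)c1ccc(Br)cc1`: 10000 nM
compound 2, `O=C(/C(=C\c1c(O)cc(O)cc1O)Sc1ccccc1Br)c1ccc(Br)cc1`: > 100000 nM
compound 3, `COc1ccc(OC)c(/C=C(/SCc2ccc(Cl)c(Cl)c2)C(=O)c2ccc(Cl)cc2)c1`: 10000 nM

Of the compounds shown here, three sharing the arylthio-enone core have been tested in a functional assay on DU-145 cells (Homo sapiens) for inhibition, read by trypan blue exclusion, with a stated time of 96 h; on this read-out higher numbers stand for weaker inhibition of growth and lower numbers for stronger inhibition of growth. Compound 1 gives 10000 nM. Compound 3 gives 10000 nM, level with compound 1 at the digits reported, a gap that lies within the usual scatter. The value for compound 2 is a limit of the assay rather than a number, > 100000 nM; compound 2 thus sits at the limit of > 100000 nM in this assay, at which 1 of the 3 values shown sits.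

The unmeasured compound 4, `O=C(/C(=C\c1c(O)cc(O)cc1O)SCc1ccc(Cl)c(Cl)c1)c1ccc(Cl)cc1`, is reached from compound 3 by a single change: 2,4,6-trihydroxyphenyl in place of 2,5-dimethoxyphenyl on a double-bonded chain carbon bound to a double-bonded chain carbon. Within the data shown here, no measured pair differs in only this place, so the size of this step is not known directly. Among the measured compounds shown here, what the numbers do show is that compound 2, the one measured compound bearing the 2,4,6-trihydroxyphenyl, gave no finite value, while compound 1 and compound 3 without it both gave numbers. The step from compound 3 to compound 4 is therefore expected to weaken inhibition of growth, a 4.0-fold higher number from compound 3 to compound 4 (0.60 log units; beyond the scatter), with a real chance that only a limit is returned. Compound 4 is estimated at 40000 nM, between 10000 nM and 200000 nM.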

Compound 4, concentration for 50% growth inhibition: 25000 nM
The estimate for compound 4 lay 1.6-fold (0.20 log units) above the measured number; measured number inside the range.
By their numbers in this assay, from the lowest: compounds 1 and 3 (each within the scatter of the next); then compound 4. At a limit, above all of these: compound 2.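

In this assay the replacement of 2,5-dimethoxyphenyl by 2,4,6-trihydroxyphenyl on a double-bonded chain carbon bound to a double-bonded chain carbon now has a direct reading (a 2.5-fold higher number from compound 3 to compound 4 (0.40 log units; beyond the scatter)), and it is a modest weakening of inhibition of growth. Among these compounds, this is the first matched pair at this position, so the size of the change no longer has to be inferred from compounds that differ in several places. Among the compounds shown here, the 2,4,6-trihydroxyphenyl group is also no longer seen only at a limit, since compound 4 carries it and still returns a number, while compound 2 remains the only compound whose result is a limit and not a number: the limit of > 100000 nM in this assay, at which 1 of the 4 values shown sits.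

For the compounds shown here, the single step cannot separate the effect of the three hydroxyl groups from that of their arrangement on the ring, and a 2,4,6-trimethoxyphenyl or an aminophenyl group at this place would help to tell these apart. From the compounds shown here alone, whether the same step holds with the other sulfur substituents and the other aryl ketones of the series also stays open, as it rests on one pair in one cell line.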